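Series notes: hydrazone cores on PC-6 cytotoxicity

The compounds below may be only part of what the source reports. "The series", "measured", "known", "first", "only" and "open" are said of these compounds alone.

Two compounds of this set carry values or entries so far. Compound 1 `COC(=O)c1ccc(/C=N/Nc2ncnc3sc(C(C)(C)C)cc23)cc1` has no result recorded: in a functional assay on PC-6 cells (Homo sapiens) for cytotoxicity, read by MTT assay, with a stated time of 3 days (a lower number here means a stronger inhibitor, a higher number a weaker inhibitor), compound 1 gives "not determined" (no result reported). Compound 2 `CC(C)(C)c1cc2c(N/N=C/c3ccc(CN)cc3)ncnc2s1` is the only compound with a number: in this assay compound 2 gives 0.214 ug/mL, so it stands alone on the numbers shown, with compound 1 as the one further entry without a single number.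

Compound 3 `CC(C)(C)c1cc2c(N/N=C/c3ccc(CO)cc3)ncnc2s1` differs from compound 2 in one place: hydroxy in place of amino on a saturated chain carbon bound to an aromatic carbon. For the measured compounds named here, no step between measured compounds is available to calibrate this change, so the expectation rests on compound 2 alone.

The change is expected to cost some potency, so a modest step towards weaker inhibition is estimated, a 1.9-fold higher number from compound 2 to compound 3 (0.27 log units; within the scatter), likely at the edge of the usual scatter rather than far beyond it. Compound 3 is therefore estimated at 0.4 ug/mL, with a range from 0.1 ug/mL to 1.5 ug/mL.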

Compound 3, half-maximal inhibitory concentration: 0.556 ug/mL
The estimate for compound 3 lay 1.4-fold (0.14 log units) below the measured number; the range from low to high includes it.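

At this position, exchanging a single heavy atom is enough to register in this assay: the change from 4-(aminomethyl)phenyl to 4-(hydroxymethyl)phenyl gives a 2.6-fold higher number from compound 2 to compound 3 (0.41 log units; beyond the scatter), although the counts of hydrogen-bond donors and acceptors stay the same. The step is modest, and compound 3 still gives 0.556 ug/mL, so activity in this cytotoxicity read-out does not rest entirely on the amino group. Nothing on hand accounts for the difference between the two groups.

Going by these compounds, whether the nitrogen itself matters, or only this particular replacement, stays open; a dimethylamino group, a carboxylic acid or a longer aminoethyl chain in the same place would help to separate these readings. A single step also cannot show whether the same change would cost as much on another core.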